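Cyclopentyl for phenyl on the thiophene-like ring of compound 2

The source may report more compounds than this note shows. Statements on the series, on what has been measured and on what is new or still open speak of the compounds shown alone.

Measured so far:
compound 1 `C=C(C)c1csc(CN[C@@H]2C[C@H]3C[C@@H]([C@H]2C)C3(C)C)c1` — 25000 nM
compound 2 `C[C@H]1[C@H](NCc2cc(-c3ccccc3)cs2)C[C@H]2C[C@@H]1C2(C)C` — 5000 nM

In an ADME assay on MDCK cells (Canis lupus familiaris) for cytotoxicity, read by microscopy, with a stated time of 48 h (on this read-out higher numbers stand for lower toxicity in this test and lower numbers for higher toxicity in this test), compound 2 stands lowest of the two numbers; its nearest neighbour is compound 1, reached by a 5.0-fold lower number from compound 1 to compound 2 (0.70 log units; beyond the scatter). Compound 3 `C[C@H]1[C@H](NCc2cc(C3CCCC3)cs2)C[C@H]2C[C@@H]1C2(C)C` differs from compound 2 by cyclopentyl in place of phenyl on an aromatic carbon. Among the compounds with values here, no measured step changes phenyl into cyclopentyl, so the only guide is the size of the one step known, which was modest. A step no larger than that, in either direction, is expected for a 1.4-fold higher number from compound 2 to compound 3 (0.15 log units; within the scatter). Compound 3 is therefore estimated at 7000 nM, within 2500 nM to 20000 nM.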

Compound 3, minimum cytotoxic concentration: 1560 nM
Compound 3: middle estimate off by 4.5-fold (0.65 log units), on the high side, outside the stated range (below it).
By their numbers in this assay, from the lowest: compound 3; then compound 2; then compound 1.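

In this assay, exchanging the aromatic ring for a saturated carbon ring at this position gives a 3.2-fold lower number from compound 2 to compound 3 (0.51 log units; beyond the scatter), although neither group carries hydrogen-bond donors, acceptors or net charge. Against 1-methylethenyl, the same cyclopentyl gives a 16-fold lower number from compound 1 to compound 3 (1.20 log units; beyond the scatter), so all three groups on this aromatic carbon are separated beyond the scatter. Nothing available explains this order of the three groups. Still open, as far as these compounds go, is where a morpholine ring or a carboxylic acid at this position would fall in this assay.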